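This account rests on a few compounds, and the source may have more. Where it says the series, first, only, none or still open, it means among the compounds named here.

In an ADME assay on L02 cells (Homo sapiens) for cytotoxicity, read by MTT assay, with a stated time of 24 h (on this read-out higher numbers stand for weaker inhibition and lower numbers for stronger inhibition), three compounds have been read so far. Compound 1 (`COc1cc(/C=C/c2ccc(OCC(=O)NCc3ccccc3)cc2)cc(OC)c1`) gives > 100000 nM, which is a limit of the assay and not a number. Compound 2 (`C=CCCCOc1ccc(/C=C/c2cc(OC)cc(OC)c2-c2cnn[nH]2)cc1`) gives > 100000 nM, again a limit. Among the measured compounds shown here, compound 3 (`COCCOc1ccc(/C=C/c2cc(OC)cc(OC)c2-c2cnn[nH]2)cc1`) gives 94500 nM, the only actual number among the three. The other two stand at the limit of > 100000 nM in this assay, at which 2 of the 3 values shown sit.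

Compound 4 (`COc1cc(/C=C/c2ccc(OCC(=O)NCc3ccccc3)cc2)c(-c2cnn[nH]2)c(OC)c1`) is still to be measured in this assay. It differs from compound 3 by benzylcarbamoyl in place of methoxymethyl on a saturated chain carbon bound to an oxygen on an aromatic ring.

For the measured compounds named here, one measured step bears on this chain, an at least 1.0-fold lower number from compound 2 to compound 3 (0.02 log units; that floor lies within the scatter). Its floor lies within the scatter, and one end of it is a limit, so it gives no measurable size for a change at this place. Going by the values given here, compound 1 also carries benzylcarbamoyl, but it offers only a limit, and no measured step covers the arrival of that group on the shared core. On that evidence, no step beyond the scatter is expected, and no direction is favoured. The expected step is a 1.1-fold lower number from compound 3 to compound 4 (0.02 log units; within the scatter). For compound 4 the estimated value is 90000 nM, with an expected range from 40000 nM to 200000 nM.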

Compound 4, half-maximal inhibitory concentration: > 100000 nM
Compound 4: a limit, no number; the forecaster's own chance of this, stated with the estimate: 60%; at least 1.1-fold (0.04 log units) between middle value and limit.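

In this assay, among the compounds shown here, the exchange on this chain gives an at least 1.0-fold higher number from compound 3 to compound 4 (0.02 log units; that floor lies within the scatter), so adding a six-membered aromatic ring of carbon only and a hydrogen-bond donor at this place produces no step that can be told from the scatter. Compound 4 gives > 100000 nM, which is a limit of the assay and not a number. The steps to compound 4 from compound 2 and from compound 1 cannot be read, and the set now gathers at one end of the read-out: the limit of > 100000 nM in this assay, at which 3 of the 4 values shown sit.

Going by these compounds, whether any group at this place can move the number in this assay beyond the scatter stays open, and a chain ending in a primary amine or a carboxylic acid would be a further test of this position. Also open, on these data alone, is what 1H-1,2,3-triazol-5-yl in place of hydrogen on an aromatic carbon does in this assay, and a value for either compound 1 or compound 4 below the limit would be needed to read it.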